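Swapping a thiazolyl amide for a pyridinyl amide on a thiazolidinedione scaffold

The source may hold more compounds than are shown below. What is called first, only, known or untested is meant among the compounds shown, and "the series" means these compounds.

Compound 1 `Cc1cnc(NC(=O)COc2ccc(/C=C3\SC(=O)NC3=O)cc2)s1` has been tested in a functional assay on KB cells (Homo sapiens) for cytotoxicity, read by sulforhodamine B assay, with a stated time of 48 h; on this read-out higher numbers stand for weaker inhibition of growth and lower numbers for stronger inhibition of growth. In this assay compound 1 reaches only a limit, < 100000 nM, not a number. Compound 2 `CCCCC1=NC2(CCCC2)C(=O)N1C(=O)COc1ccc(/C=C2/SC(=O)NC2=O)cc1` likewise shows only a limit in this assay, < 100000 nM. Both values therefore sit at the limit, as the limit of < 100000 nM in this assay, at which 2 of the 2 values shown sit, records. Compound 3 `O=C(COc1ccc(/C=C2\SC(=O)NC2=O)cc1)Nc1ccccn1` differs from compound 1 by pyridin-2-yl in place of 5-methyl-1,3-thiazol-2-yl on an amide-type nitrogen. Among the measured compounds shown here, with no measured step to lean on, the expected change a step that the limit leaves unreadable from compound 1 to compound 3 is none beyond the scatter. For compound 3 the estimated value in this assay is 30000 nM, between 5000 nM and 100000 nM.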

Compound 3, concentration for 50% growth inhibition: < 100000 nM
Compound 3 gave a limit, no number; the forecaster's own chance of this, stated with the estimate: 60%; the middle value lies beyond the limit too.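

Among the compounds shown here, compound 1 and compound 3 both give only a limit in this assay, so no step between them can be read: the limit of < 100000 nM in this assay, at which 3 of the 3 values shown sit. The compounds shown leave open whether pyridin-2-yl and 5-methyl-1,3-thiazol-2-yl on the amide-type nitrogen differ in their inhibition of growth.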